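Swapping chloro for trifluoromethyl on the anilino ring

The source may report more compounds than this note shows. Statements on the series, on what has been measured and on what is new or still open speak of the compounds shown alone.

Measured compounds:
Compound 1 `COc1ccc(Nc2nc(SCc3cn(CC(=O)NC(=O)Nc4ccccn4)nn3)nc(-c3ccc(C)cc3)c2C#N)cc1`: 23400 nM
Compound 2 `COc1ccccc1Nc1nc(SCc2cn(CC(=O)NC(=O)Nc3ccccn3)nn2)nc(-c2ccc(C)cc2)c1C#N`: 19700 nM
Compound 3 `Cc1ccc(-c2nc(SCc3cn(CC(=O)NC(=O)Nc4ccccn4)nn3)nc(Nc3cccc(Cl)c3)c2C#N)cc1`: 14900 nM

All three compounds were tested in a functional assay on MCF7 cells (Homo sapiens) for inhibition, read by MTT assay, with a stated time of 72 h; a higher number here means a weaker inhibitor, a lower number a stronger inhibitor. They share one core and differ only in the aryl group on the ring nitrogen. Compound 3 is not set apart from the other two beyond the scatter: a 1.6-fold lower number from compound 1 to compound 3 (0.20 log units; within the scatter) and a 1.3-fold lower number from compound 2 to compound 3 (0.12 log units; within the scatter), and likewise a 1.2-fold lower number from compound 1 to compound 2 (0.07 log units; within the scatter). The three numbers therefore stand together.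

Compound 4 `Cc1ccc(-c2nc(SCc3cn(CC(=O)NC(=O)Nc4ccccn4)nn3)nc(Nc3cccc(C(F)(F)F)c3)c2C#N)cc1` has not yet been measured. It differs from compound 3 in one place: trifluoromethyl in place of chloro on an aromatic carbon. For the measured compounds named here, none of the measured steps exchanges one substituent for another on the same aryl ring; the three steps exchange the whole aryl group, and each stayed within the scatter. On that basis no step beyond the scatter is expected in this assay for the change to compound 4, and the expected step is a 1.1-fold lower number from compound 3 to compound 4 (0.03 log units; within the scatter). Compound 4 is estimated at 14000 nM, with a range from 6000 nM to 35000 nM.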

Compound 4, half-maximal inhibitory concentration: 6120 nM
Compound 4: middle estimate off by 2.3-fold (0.36 log units), on the high side; low and high end bracket the measured number.
By their numbers in this assay, from the lowest: compound 4; then compounds 3, 2 and 1 (each within the scatter of the next).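

Until now, exchanging the whole aryl group on the nitrogen had not moved the number in this assay beyond the scatter, yet exchanging only chloro for trifluoromethyl on an otherwise unchanged phenyl ring gives a 2.4-fold lower number from compound 3 to compound 4 (0.39 log units; beyond the scatter) as a step beyond it. The 3-(trifluoromethyl)phenyl group also stands apart from both methoxyphenyl groups, with a 3.2-fold lower number from compound 2 to compound 4 (0.51 log units; beyond the scatter) and a 3.8-fold lower number from compound 1 to compound 4 (0.58 log units; beyond the scatter) as its steps, so compound 4 is the strongest inhibitor of the four and the first to separate from the rest.

Still open, from the compounds shown here alone, is whether trifluoromethyl would give a similar step on another carbon of this ring, and how an amine, a carboxylic acid or a single fluorine on this same carbon would compare. No measurement available here explains why trifluoromethyl gives the lower number.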